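The source may report more compounds than this note shows. Statements on the series, on what has been measured and on what is new or still open speak of the compounds shown alone.

Working notes on the series. Three compounds of the shared core have been run in a functional assay on HeLa cells (Homo sapiens) for antiproliferative activity, read by CCK-8 assay, with a stated time of 72 h, tested at 8 uM; on this read-out lower numbers stand for a weaker effect and higher numbers for a stronger effect at the one concentration tested. Compound 1 `Nc1ccccc1NC(=O)c1ccc(CSC(=S)N2CCc3ccc([N+](=O)[O-])cc32)cc1` gives 62.1% in this assay, which is the second highest of the three numbers in hand. The nearest number belongs to compound 3 `Nc1ccccc1NC(=O)c1ccc(CSC(=S)N2CCN(c3ccncc3)CC2)cc1`, which gives 77.4% in this assay, a gap above compound 1 that goes beyond the usual scatter. The furthest belongs to compound 2 `Nc1ccccc1NC(=O)c1ccc(CSC(=S)N2CCN(C(c3ccccc3)c3ccccc3)CC2)cc1`, which gives 13.8% in this assay, a gap below compound 1 that also goes beyond the scatter. Among the measured compounds shown here, no two measured compounds differ in one place only, so no measured step is available to lean on.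

Compound 4 `Nc1ccccc1NC(=O)c1ccc(CSC(=S)N2CCc3ccccc32)cc1` is not yet measured. It differs from compound 1 by hydrogen in place of nitro on an aromatic carbon. For the measured compounds named here, with no comparable step among the measured compounds, the step is estimated to be small, with a modest fall or none beyond the scatter; the expected step in this assay is a number 10.1 percentage points lower from compound 1 to compound 4 (beyond the scatter). Compound 4 is expected to give about 52% in this assay, within a range of 32% to 70%.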

Compound 4, a percentage reported as inhibition, at one concentration (the size of the read-out at that concentration, not a potency): 67%
The estimate for compound 4 lay 15 percentage points below the measured number; measured number inside the range.
By their numbers in this assay, from the lowest: compound 2; then compounds 1 and 4 (each within the scatter of the next); then compound 3.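

In this assay, hydrogen in place of nitro on this aromatic carbon gives a number 4.9 percentage points higher from compound 1 to compound 4 (within the scatter), so the effect at the one concentration tested does not depend on the nitro group at this position. Among the compounds shown here, this is the only measured step so far, and it shows that this change, which removes a group of three heavy atoms, leaves the read-out within the usual scatter. Nothing in hand accounts for this result.

From the compounds shown here alone, whether other groups on this aromatic carbon, such as an amine, a methoxy group or a carboxylic acid, would also leave the read-out unchanged remains open. Also open, going by these compounds, is whether compound 1 and compound 4 would stay level at other concentrations, since a single-concentration read-out is not a measure of potency.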